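Fluoro on the aryl ring of compound 1

The source may report more compounds than this note shows. Statements on the series, on what has been measured and on what is new or still open speak of the compounds shown alone.

Measured so far:
compound 1, `CC(C)C1CC(=O)c2s/c(=N/c3ccccc3)oc2C1`, 2190 nM
compound 2, `CC1(C)CC(=O)c2s/c(=N/C3CCCCC3)oc2C1`, 12700 nM
compound 3, `CC1CC(=O)c2s/c(=N/c3ccc(Cl)cc3)oc2C1`, 16500 nM

In a functional assay on PC-3 cells (Homo sapiens) for antiproliferative activity, read by sulforhodamine B assay (on this read-out lower numbers stand for stronger inhibition of growth and higher numbers for weaker inhibition of growth), compound 1 gives the lowest of the three numbers. Among the compounds with values here, compound 2 and compound 3 both stand well beyond the scatter above it, but each differs from compound 1 in more than one place, so no single step between measured compounds can be read off.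

Compound 4, `CC(C)C1CC(=O)c2s/c(=N/c3ccc(F)cc3)oc2C1`, differs from compound 1 by fluoro in place of hydrogen on an aromatic carbon. Within the data shown here, no measured pair shows this change on its own. Without a shown step, no direction can be claimed; the step from compound 1 to compound 4 is expected to stay within the scatter, a 1.1-fold higher number from compound 1 to compound 4 (0.06 log units; within the scatter). Compound 4 is therefore expected at 2500 nM in this assay, with a range from 900 nM to 7000 nM.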

Compound 4, concentration for 50% growth inhibition: 2760 nM
Beside the measured number, compound 4's estimate is 1.1-fold (0.04 log units) below it; the measured number falls inside the stated range.
By their numbers in this assay, from the lowest: compounds 1 and 4 (each within the scatter of the next); then compounds 2 and 3 (each within the scatter of the next).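

In this assay, within the data shown here, fluoro in place of hydrogen gives a 1.3-fold higher number from compound 1 to compound 4 (0.10 log units; within the scatter), the first step here that changes one place only. At this position, on an aromatic carbon and para to a large group, the phenyl to 4-fluorophenyl change therefore moves the number no further than the scatter. Nothing measured here accounts for this result. The compounds shown leave open whether a larger or different group in the same place, such as methoxy, an amine or a carboxylic acid, would also stay within the scatter.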